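The source may hold more compounds than are shown below. What is called first, only, known or untested is meant among the compounds shown, and "the series" means these compounds.

Measured so far:
Compound 1 `O=C1c2ccccc2N(Cc2ccccc2)S(=O)(=O)N1COCc1ccccc1` gives 100000 nM in a functional assay on CCRF-CEM cells (Homo sapiens) for inhibition; on this read-out lower numbers stand for higher toxicity in this test and higher numbers for lower toxicity in this test.
Compound 2 `O=S1(=O)N=C(OCc2ccccc2)c2ccccc2N1Cc1ccccc1` gives 22200 nM in this assay.
Compound 3 `O=C1c2ccccc2N(Cc2ccccc2Cl)S(=O)(=O)N1Cc1ccccc1Cl` gives 40400 nM in this assay.

Among these three, compound 1 has the highest number, so it is the least toxic of the set in this assay. Compound 3 sits nearest to it, and that gap is already beyond the usual scatter of repeated measurements. Compound 2 lies furthest away, also beyond the scatter. All three compounds share one core, and their differences lie in the groups hanging off it.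

The step now followed leads from compound 1 to compound 4 `O=C1c2ccccc2N(Cc2ccccc2)S(=O)(=O)N1Cc1ccc(Cl)cc1`, which has not yet been measured in this assay. The change is 4-chlorophenyl in place of benzyloxy on a saturated chain carbon bound to an amide-type nitrogen in a ring. Among the measured compounds shown here, no two of the measured compounds differ in exactly one place, so no directly comparable step is at hand. Still, compound 3, which carries chlorine-bearing groups, gives 40400 nM, a lower number than compound 1. On that basis the estimated step is a 2.5-fold lower number from compound 1 to compound 4 (0.40 log units; beyond the scatter), a modest move toward a lower number. Compound 4 is therefore estimated at 40000 nM, within a range from 15000 nM to 100000 nM.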

Compound 4, half-maximal cytotoxic concentration: 27800 nM
For compound 4 the middle estimate is 1.4-fold (0.16 log units) above the measured one; low and high end bracket the measured number.
By their numbers in this assay, from the lowest: compounds 2, 4 and 3 (each within the scatter of the next); then compound 1.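

In this assay, putting 4-chlorophenyl in place of benzyloxy on a saturated chain carbon bound to an amide-type nitrogen in a ring gives a 3.6-fold lower number from compound 1 to compound 4 (0.56 log units; beyond the scatter) and so moves toward higher toxicity in this test. Among the compounds shown here, this is the first comparison in the set in which only one place changes, and it shows that this position can shift the read-out by more than the usual scatter. Both groups contain one six-membered aromatic ring of carbon only, so the change lies elsewhere: the oxygen, which is the hydrogen-bond acceptor, leaves and a chlorine enters, and no measurement here explains why the number moves or separates these two changes.

The compounds shown leave open whether the oxygen's departure, the chlorine's arrival or both drive the step, a question that a plain benzyl or a 4-fluorobenzyl at this place could help to settle. They also leave open how the number would respond to a group carrying an amine or a carboxylic acid here, or to a longer chain between the ring nitrogen and the aromatic ring.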